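Methyl for fluoro on the aryl group of compound 2

The compounds below may be only part of what the source reports. "The series", "measured", "known", "first", "only" and "open" are said of these compounds alone.

Compound 1 `CCCCC#Cc1cc([C@@H]2O[C@H](CO)[C@@H](O)[C@H]2O)n2ncnc(N)c12`: 1000 nM
Compound 2 `Nc1ncnn2c([C@@H]3O[C@H](CO)[C@@H](O)[C@H]3O)cc(-c3ccccc3F)c12`: > 100000 nM, a limit of the assay

In a functional assay on CAPAN-1 cells (Homo sapiens) for antiproliferative activity, with a stated time of 72 h (on this read-out lower numbers stand for stronger inhibition and higher numbers for weaker inhibition), compound 1 gives 1000 nM. For compound 2 this assay reports > 100000 nM, which is a limit rather than a number, so compound 2 stands at the limit of > 100000 nM in this assay, at which 1 of the 2 values shown sits. Among the measured compounds shown here, the single measured step, an at least 100-fold higher number from compound 1 to compound 2 (2.00 log units; beyond the scatter), concerns a different replacement. Compound 3 `Cc1ccccc1-c1cc([C@@H]2O[C@H](CO)[C@@H](O)[C@H]2O)n2ncnc(N)c12` differs from compound 2 by methyl in place of fluoro on an aromatic carbon. For the measured compounds named here, no measured step bears on this change. Compound 3 is therefore expected to remain near the limit, a step that the limit leaves unreadable from compound 2 to compound 3. The value of compound 3 in this assay is estimated at 150000 nM, within 30000 nM to 1000000 nM.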

Compound 3, half-maximal inhibitory concentration: 97500 nM
Estimate against measurement, compound 3: 1.5-fold (0.19 log units) above; the measured number falls inside the stated range.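

In this assay, among the compounds shown here, 2-methylphenyl gives the first value that is a true number for an aryl group at this position, and the replacement of hex-1-yn-1-yl now has a measured size: a 98-fold higher number from compound 1 to compound 3 (1.99 log units; beyond the scatter). Methyl in place of fluoro shows no change that can be claimed, with an at least 1.0-fold lower number from compound 2 to compound 3 (0.01 log units; that floor lies within the scatter). Compound 2 remains a limit of the assay: the limit of > 100000 nM in this assay, at which 1 of the 3 values shown sits.

Going by these compounds, whether a plain phenyl, or a phenyl carrying an amine, would move the number back towards that of compound 1 stays open. So does whether a longer alkynyl chain than hex-1-yn-1-yl would hold or improve on it.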